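Swapping Methyl for Nitro on a Partly Saturated Core

The source may hold more compounds than are shown below. What is called first, only, known or untested is meant among the compounds shown, and "the series" means these compounds.

Compound 2 `CC1=CC[C@H](C(C)C)c2cc(C)c(OC(=O)c3cccc(C)c3)cc21` has no number to stand on: in a functional assay on SK-LU-1 cells (Homo sapiens) for antiproliferative activity, read by sulforhodamine B assay, with a stated time of 48 h, tested at 50 uM (a lower number here means less inhibition, a higher number more inhibition at the concentration tested (going by the name of the read-out)), compound 2 is reported only as "not active" (no number reported), so its place on the scale is known just as an absence of effect. Compound 4 `CC1=CC[C@H](C(C)C)c2cc(C)c(OC(=O)c3cccc([N+](=O)[O-])c3)cc21` differs from it in a single spot: nitro in place of methyl on an aromatic carbon. Two compounds built on a different, fully aromatic core were also measured. Compound 1 `Cc1cc2c(C(C)C)ccc(C)c2cc1OC(=O)c1cccc(C(F)(F)F)c1` gives 17.3% in this assay, while compound 3 `Cc1cc2c(C(C)C)ccc(C)c2cc1OC(=O)c1ccc([N+](=O)[O-])cc1`, which also carries a nitro group, gives 100%. Among the compounds with values here, no measured pair shows this exact exchange, so the size of the step is uncertain; an increase beyond the usual scatter is expected rather than no change. Compound 4 is therefore estimated at 45%, with a range from 10% to 90%.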

Compound 4, a percentage reported as inhibition, at one concentration (the size of the read-out at that concentration, not a potency): 60.4%
Compound 4: the middle estimate sits 15.4 percentage points below what was measured; the measured number falls inside the stated range.
By their numbers in this assay, from the lowest: compound 1; then compound 4; then compound 3.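

Within the data shown here, compound 2 is reported only as "not active", without a number, so no step from it to compound 4 can be read. The compounds shown leave open how large the exchange of methyl for nitro is on this core. Nothing measured here explains the result of compound 4.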